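A few compounds are considered here, and "the series" means these few. Any claim that something is new, unique, unknown or untested is made for them only; others in the source may bear on it.

Measured compounds:
Compound 1 `NS(=O)(=O)c1ccccc1-c1cnc(C(=O)CCCCCCc2ccccc2)o1` gives 1500 nM in an assay (Rattus norvegicus) for inhibition of Fatty-acid amide hydrolase 1 (Homo sapiens); on this read-out higher numbers stand for weaker inhibition and lower numbers for stronger inhibition.
Compound 2 `O=C(CCCCCCc1ccccc1)c1ncc(-c2ccc(F)cc2)o1` gives 62 nM in this assay.
Compound 3 `NS(=O)(=O)c1ccc(-c2cnc(C(=O)CCCCCCc3ccccc3)o2)cc1` gives 10 nM in this assay.

Among these three, compound 2 holds the second highest number: compound 3 lies a 6.2-fold lower number from compound 2 to compound 3 (0.79 log units; beyond the scatter) away, and compound 1 shows a much higher number. The only shown step, a 6.2-fold lower number from compound 2 to compound 3 (0.79 log units; beyond the scatter), swaps one group on the aryl ring for another; compound 1, whose number is compared with compound 2 only by its value, keeps an aryl ring too, placed differently.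

Compound 4 `CNC(=O)c1cnc(C(=O)CCCCCCc2ccccc2)o1` is reached from compound 2 by methylcarbamoyl in place of 4-fluorophenyl on an aromatic carbon. Here the aryl ring itself goes away and a small amide takes its place on the shared core. No measured step removes this ring, so nothing shown bears directly on the change, and any expectation rests on the observation that all three measured compounds carry an aryl ring at that position and that their numbers span a wide range even so. The step is expected to raise the number: a 16-fold higher number from compound 2 to compound 4 (1.21 log units; beyond the scatter). Compound 4 is therefore estimated at 1000 nM, within 200 nM to 5000 nM.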

Compound 4, inhibition constant: 7 nM
Compound 4: the middle estimate sits 140-fold (2.15 log units) above what was measured, outside the stated range (below it).
By their numbers in this assay, from the lowest: compounds 4 and 3 (each within the scatter of the next); then compound 2; then compound 1.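

In this assay the swap of 4-fluorophenyl for methylcarbamoyl gives an 8.9-fold lower number from compound 2 to compound 4 (0.95 log units; beyond the scatter) and so shows that an aryl ring is not required at this position on the shared core. All three earlier compounds carried such a ring, whereas here a smaller group with no ring keeps the number low: compound 4 at 7 nM and compound 3 at 10 nM lie within the usual scatter of each other. No measured evidence shown here accounts for this step.

The compounds shown cannot separate the part played by the amide hydrogen from that of the carbonyl or the methyl group. Going by these compounds, how this position responds to a carboxylic acid, an ester, an amine or a longer alkyl chain on the amide nitrogen also stays open.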